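Ester to acid on the oxime side chain

The source may hold more compounds than are shown below. What is called first, only, known or untested is meant among the compounds shown, and "the series" means these compounds.

The three measured compounds share one core, seen in compound 1 `COc1ccc(/C(=N/O)c2cccc3ccccc23)c(OC)c1OC`, compound 2 `CCOC(=O)CO/N=C(/c1ccc(OC)c(OC)c1OC)c1cccc2ccccc12` and compound 3 `COc1ccc(C(O)(Cc2ccc(F)cc2)c2cccc3ccccc23)c(OC)c1OC`. In a functional assay on MDA-MB-231 cells (Homo sapiens) for inhibition, read by sulforhodamine B assay, with a stated time of 48 h (a higher number here means a weaker inhibitor, a lower number a stronger inhibitor), compound 1 gives 2500 nM, compound 3 gives 5440 nM, and compound 2 gives 16400 nM, the highest number of the three, standing beyond the scatter above both of the others. For the measured compounds named here, the one step between measured compounds, a 6.6-fold higher number from compound 1 to compound 2 (0.82 log units; beyond the scatter), shows that building out the oxygen of the oxime into the ester chain weakened inhibition. Compound 4 `COc1ccc(/C(=N/OCC(=O)O)c2cccc3ccccc23)c(OC)c1OC` differs from compound 2 by hydrogen in place of ethyl on an oxygen next to a carbonyl group. Going by the values given here, no measured pair shows an ethyl removed from such an oxygen, so that step is only a loose guide: it says the chain on that oxygen costs potency, but not how the free acid compares with the ester. He therefore expects compound 4 to stay near compound 2, with a step of a 1.2-fold higher number from compound 2 to compound 4 (0.09 log units; within the scatter) that need not pass the scatter, and estimates for compound 4 a value of 20000 nM, within 6000 nM to 70000 nM.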

Compound 4, half-maximal inhibitory concentration: > 20000 nM
Compound 4 was reported as a limit; the forecaster's own chance of this, stated with the estimate: 15%; the middle value sits exactly at the limit.
By their numbers in this assay, from the lowest: compound 1; then compound 3; then compound 2. At a limit, above all of these: compound 4.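

The value for compound 4 in this assay is a limit and not a number: the limit of > 20000 nM in this assay, at which 1 of the 4 values shown sits. Hydrogen in place of ethyl gives an at least 1.2-fold higher number from compound 2 to compound 4 (0.08 log units; that floor lies within the scatter), so this floor does not show whether the free acid differs from the ester. Carboxymethyl in place of hydrogen on an oxygen gives an at least 8.0-fold higher number from compound 1 to compound 4 (0.90 log units; beyond the scatter), which shows that the loss seen with the (ethoxycarbonyl)methyl chain in compound 2 is also seen with the carboxymethyl chain, and so does not depend on the ethyl being present.

The compounds shown leave open the true value of compound 4, and with it the size of the change from ester to acid. They also leave open whether a plain methyl on the same oxygen, or a chain ending in an amine, would stay close to compound 1.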